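Sulfur-linked and sulfonyl-linked anilides: pentafluorosulfanyl to trifluoromethyl

The source may hold more compounds than are shown below. What is called first, only, known or untested is meant among the compounds shown, and "the series" means these compounds.

Measured compounds:
- compound 1, `O=C(Nc1cccc(S(F)(F)(F)(F)F)c1)c1ccc(Sc2ccc(O)cc2)cc1`: 4350 nM
- compound 2, `O=C(Nc1cccc(C(F)(F)F)c1)c1ccc(Sc2ccc(O)cc2)cc1`: 5950 nM
- compound 3, `O=C(Nc1ccc(S(F)(F)(F)(F)F)cc1)c1ccc(S(=O)(=O)c2ccc(O)cc2)cc1`: 10900 nM

Read-out throughout is a functional assay on DU-145 cells (Homo sapiens) for antiproliferative activity, read by fluorescence and propidium iodide staining, with a stated time of 96 h; a higher number here means a weaker inhibitor, a lower number a stronger inhibitor. Compound 4, `O=C(Nc1ccc(C(F)(F)F)cc1)c1ccc(S(=O)(=O)c2ccc(O)cc2)cc1`, is not yet measured.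

Compound 1 and compound 2 share a core and differ in one place: a group of 4 heavy atoms (1 carbon, 3 fluorine; no ring) in place of a group of 6 heavy atoms (5 fluorine, 1 sulfur; no ring), on an aromatic carbon. The step this made was a 1.4-fold higher number from compound 1 to compound 2 (0.14 log units; within the scatter). Compound 3 carries a different core from compound 1; the difference between the two cores is not broken down here. Compound 3 stands at the highest of the three numbers, but its gap to compound 2 is within the scatter, and only its gap to compound 1 is beyond it, so no ordering of compound 2 and compound 3 is claimed.

From compound 3 to compound 4 the change is a group of 4 heavy atoms (1 carbon, 3 fluorine; no ring) in place of a group of 6 heavy atoms (5 fluorine, 1 sulfur; no ring), on an aromatic carbon. The place lines are not the same word for word: in compound 1 and compound 2 the group sits "meta to a large group", in compound 3 and compound 4 "para to a large group", so this is the same kind of change, not the same change. For the measured compounds named here, compound 4 is expected to move by about a 1.3-fold higher number from compound 3 to compound 4 (0.11 log units; within the scatter), a small step, because compound 1 to compound 2 gave a 1.4-fold higher number from compound 1 to compound 2 (0.14 log units; within the scatter) and that is the only measured instance of this kind of change. Compound 4 is therefore estimated at 14000 nM, with a plausible range of 6000 nM to 35000 nM.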

Compound 4, half-maximal inhibitory concentration: 30700 nM
The estimate for compound 4 lay 2.2-fold (0.34 log units) below the measured number; measured number inside the range.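

On the second core in this assay, trifluoromethyl in place of pentafluorosulfanyl gave a 2.8-fold higher number from compound 3 to compound 4 (0.45 log units; beyond the scatter), so this step lies beyond the scatter, whereas the earlier step on the first core lies within it. For the compounds shown here, that contrast is not firm, however, since the two steps themselves do not separate when set side by side, and as far as these pairs can tell, the change carries from one core to the other without a demonstrable difference in size: the same change on two cores in this assay, a 1.4-fold higher number (0.14 log units; within the scatter) from compound 1 to compound 2 and a 2.8-fold higher number (0.45 log units; beyond the scatter) from compound 3 to compound 4, 2.1-fold (0.31 log units) apart, within the scatter of two such steps This does not show that the step is constant across the series, as it rests on only two pairs, and those pairs differ both in core and in where the group sits, so any effect of the core cannot be separated from an effect of place.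

The compounds shown leave open how the two groups compare at one and the same place on both cores, which would separate core from place. Also open, as far as these compounds go, is whether a nitrile or a longer alkyl chain at that place, or an amine or a carboxylic acid in place of the hydroxyl group, would leave the size of this step unchanged.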